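Benzylamine variation in a bis(trifluoromethyl)benzenesulfonamide series

The compounds below may be only part of what the source reports. "The series", "measured", "known", "first", "only" and "open" are said of these compounds alone.

Measured so far in a functional assay on HT-29 cells (Homo sapiens) for inhibition, read by MTT assay, with a stated time of 72 h; on this read-out lower numbers stand for stronger inhibition of growth and higher numbers for weaker inhibition of growth:
- compound 1, `O=S(=O)(NCCCNCc1cccc2ccccc12)c1cc(C(F)(F)F)cc(C(F)(F)F)c1`: 2600 nM
- compound 2, `COc1cccc(CNCCCNS(=O)(=O)c2cc(C(F)(F)F)cc(C(F)(F)F)c2)c1`: 10000 nM
- compound 3, `O=S(=O)(NCCCNCc1ccc(C(F)(F)F)cc1)c1cc(C(F)(F)F)cc(C(F)(F)F)c1`: 2900 nM

All three share one core and differ only in the aryl group on a saturated chain carbon bound to an amine nitrogen. Compound 2 stands at the highest number of the three: its nearest neighbour is compound 3, with a 3.4-fold lower number from compound 2 to compound 3 (0.54 log units; beyond the scatter), and the furthest is compound 1, with a 3.8-fold higher number from compound 1 to compound 2 (0.59 log units; beyond the scatter) read in reverse. Between compound 1 and compound 3 there is a 1.1-fold higher number from compound 1 to compound 3 (0.05 log units; within the scatter), so those two sit together and compound 2 sits apart.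

The step to the untested compound 4, `O=S(=O)(NCCCNCc1ccc(Br)cc1)c1cc(C(F)(F)F)cc(C(F)(F)F)c1`, is 4-bromophenyl in place of 3-methoxyphenyl on a saturated chain carbon bound to an amine nitrogen. For the measured compounds named here, the step that bears most directly on it is the one from compound 2 to compound 3, where one six-membered aromatic ring of carbon only replaces another and the number drops by a 3.4-fold lower number from compound 2 to compound 3 (0.54 log units; beyond the scatter). Compound 4 again carries a single substituent on a six-membered aromatic ring of carbon only, as compound 3 does, so a drop of similar size in this assay is expected rather than none beyond the scatter.

Compound 4 is therefore estimated at 3200 nM, within 1600 nM to 7000 nM, which would mean an expected step of a 3.1-fold lower number from compound 2 to compound 4 (0.49 log units; beyond the scatter).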

Compound 4, concentration for 50% growth inhibition: 2200 nM
For compound 4 the middle estimate is 1.5-fold (0.16 log units) above the measured one; measured number inside the range.
By their numbers in this assay, from the lowest: compounds 4, 1 and 3 (each within the scatter of the next); then compound 2.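

In this assay, 4-bromophenyl in place of 3-methoxyphenyl on a saturated chain carbon bound to an amine nitrogen gives a 4.5-fold lower number from compound 2 to compound 4 (0.66 log units; beyond the scatter) and so adds a third aryl group that stands apart from compound 2. Bromo in place of trifluoromethyl on an aromatic carbon gives a 1.3-fold lower number from compound 3 to compound 4 (0.12 log units; within the scatter) and 4-bromophenyl in place of naphthalen-1-yl gives a 1.2-fold lower number from compound 1 to compound 4 (0.07 log units; within the scatter) in the same assay, so compounds 1, 3 and 4 sit together despite three different aryl groups, and among the four compounds only compound 2, the sole carrier of 3-methoxyphenyl, lies apart. No supporting measurement accompanies this result, and the separation of compound 2 stays an observation on these numbers alone.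

A 4-methoxyphenyl or 3-bromophenyl group on the same carbon would show whether the gap follows the methoxy group itself or the place of the substituent on the ring. Going by these compounds, whether the flat response among compounds 1, 3 and 4 would hold for an unsubstituted phenyl, for a ring bearing a carboxylic acid, or with a longer chain in the shared core remains open.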